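This account rests on a few compounds, and the source may have more. Where it says the series, first, only, none or still open, it means among the compounds named here.

The measured compounds and their values in a functional assay on KB cells (Homo sapiens) for cytotoxicity, read by sulforhodamine B assay; on this read-out lower numbers stand for an effect already at smaller amounts and higher numbers for an effect only at larger amounts of compound:

Compound 1, `C=C1CC[C@@H]2[C@](C)(COC(C)=O)[C@H](OC(C)=O)CC[C@@]2(C)[C@@H]1C/C=C1/C(=O)OC[C@H]1OC(C)=O`: 11.6 uM
Compound 2, `C=C1CC[C@@H]2[C@](C)(CO)[C@H](OC(C)=O)CC[C@@]2(C)[C@@H]1C/C=C1/C(=O)OC[C@H]1OC(C)=O`: 11.7 uM
Compound 3, `C=C1CC[C@@H]2[C@](C)(CO[Si](c3ccccc3)(c3ccccc3)C(C)(C)C)[C@H](OC(C)=O)CC[C@@]2(C)[C@@H]1C/C=C1/C(=O)OC[C@H]1OC(C)=O`: 29 uM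

Compound 2 differs from compound 1 by hydrogen in place of acetyl on an oxygen on a saturated carbon; this step gave a 1.0-fold higher number from compound 1 to compound 2 (0.00 log units; within the scatter). Compound 4, `C=C1CC[C@@H]2[C@](C)(CO[Si](c3ccccc3)(c3ccccc3)C(C)(C)C)[C@H](O)CC[C@@]2(C)[C@@H]1C/C=C1/C(=O)OC[C@H]1OC(C)=O`, is not yet measured. It differs from compound 3 by hydrogen in place of acetyl on an oxygen on a saturated carbon. The difference between the core of compound 3 and the core of compound 1 is not broken down here. The two places are not identical: in compound 1 the oxygen sits on a saturated carbon whose other neighbour is a saturated chain carbon, in compound 3 on one whose other neighbour is a saturated ring carbon, so the change is of the same kind rather than the same. Compound 4 is expected to show no change at the digits printed from compound 3 to compound 4 (within the scatter), because compound 2 showed a 1.0-fold higher number from compound 1 to compound 2 (0.00 log units; within the scatter). Compound 4 is therefore estimated at 29 uM.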

Compound 4, concentration for half-maximal effect: 10.5 uM
Beside the measured number, compound 4's estimate is 2.8-fold (0.44 log units) above it; measured number below the stated range.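

In this assay the acetoxy to hydroxy change gave a 2.8-fold lower number from compound 3 to compound 4 (0.44 log units; beyond the scatter), a modest step. Set beside the earlier pair, the change does not carry over at one size from one core to the other: the same change on two cores in this assay, a 1.0-fold higher number (0.00 log units; within the scatter) from compound 1 to compound 2 and a 2.8-fold lower number (0.44 log units; beyond the scatter) from compound 3 to compound 4, 2.8-fold (0.44 log units) apart, beyond the scatter of two such steps

This shows that a flat result on one core cannot simply be transferred to another in this series, but two pairs do not show whether the gap follows from the different place of the change or from the rest of the core, nor how the change would behave on any further core.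

The compounds shown leave open what an amine or a carboxylic acid in place of the hydroxy would give. They also leave open whether an ester with a longer chain would behave as the acetyl does.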